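The source may hold more compounds than are shown below. What is called first, only, known or untested is meant among the compounds shown, and "the series" means these compounds.

Compound 3 `N#CC1=C(N)N(c2ccc(S(N)(=O)=O)cc2)C2=C(C(=O)CCC2)C1c1ccc(Cl)cc1Cl` gives 50% in a functional assay on Ehrlich cells (Mus musculus) for antiproliferative activity, read by trypan blue exclusion, with a stated time of 2 h, tested at 25 ug/mL; on this read-out lower numbers stand for a weaker effect and higher numbers for a stronger effect at the one concentration tested. Compound 1 `COc1cc(CC2C(C#N)=C(N)N(c3ccc(S(N)(=O)=O)cc3)C3=C2C(=O)CCC3)ccc1O` gives 50% in this assay, and compound 3 sits level with it, the two sharing the low end of the three numbers (no change at the digits printed from compound 1 to compound 3 (within the scatter)). Within the data shown here, compound 2 `N#CC1=C(N)N(c2ccc(S(N)(=O)=O)cc2)C2=C(C(=O)CCC2)C1c1ccc([N+](=O)[O-])cc1` gives 80% in this assay, the only value that stands apart (a number 30 percentage points lower from compound 2 to compound 3 (beyond the scatter), a number 30 percentage points higher from compound 1 to compound 2 (beyond the scatter)).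

Compound 4 `N#CC1=C(N)N(c2ccc(S(N)(=O)=O)cc2)C2=C(C(=O)CCC2)C1c1ccco1` has not been measured. It differs from compound 3 in one place: furan-2-yl in place of 2,4-dichlorophenyl on a saturated ring carbon.

The two steps that bear on this change are those that swap the group on the same saturated ring carbon: from compound 1 to compound 3 nothing moved beyond the scatter, while from compound 2 to compound 3 the number fell by a modest amount. Among the measured compounds shown here, no measured compound carries furan-2-yl, so no direction can be read from the data. Compound 4 is therefore expected to stay near compound 3 in this assay, with a number 5 percentage points higher from compound 3 to compound 4 (within the scatter), giving an estimate of 55%, between 35% and 75%.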

Compound 4, a percentage reported as activity, at one concentration (the size of the read-out at that concentration, not a potency): 0%
Beside the measured number, compound 4's estimate is 55 percentage points above it; measured number outside the range, below it.
By their numbers in this assay, from the lowest: compound 4; then compounds 1 and 3 (each within the scatter of the next); then compound 2.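

In this assay, among these compounds, the group on the saturated ring carbon decides more than the earlier compounds showed: furan-2-yl gives a number 50 percentage points lower from compound 3 to compound 4 (beyond the scatter) and a number 50 percentage points lower from compound 1 to compound 4 (beyond the scatter) and also a number 80 percentage points lower from compound 2 to compound 4 (beyond the scatter), so this position can lose the whole read-out rather than merely shift it within the range of the earlier compounds. Among the compounds shown, the one five-membered aromatic ring with a hetero atom stands apart from the 2,4-dichlorophenyl, 4-nitrophenyl and 4-hydroxy-3-methoxybenzyl groups, all of which keep a clear effect. No supporting measurement accounts for this drop.

The compounds shown cannot separate the ring oxygen from the smaller ring or the lost substituents. From the compounds shown here alone, that question stays open without a thiophen-2-yl group or an unsubstituted phenyl group at this carbon.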